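The compounds below may be only part of what the source reports. "The series", "measured", "known", "first", "only" and "open" are said of these compounds alone.

The measurements come from a functional assay on HuCC-A1 cells (Homo sapiens) for cytotoxicity, read by MTT assay, with a stated time of 48 h; on this read-out lower numbers stand for stronger inhibition and higher numbers for weaker inhibition. Compound 1 has the structure `Cc1ccccc1OCc1cn(-c2ccc(S(=O)(=O)N3CCc4ccccc4C3)cc2)nn1`. In this assay compound 1 gives > 50 ug/mL, which is a limit of the assay and not a measured number. Compound 2 has the structure `COc1cc2c(cc1OC)CN(S(=O)(=O)c1ccc(-n3cc(COc4ccc([N+](=O)[O-])cc4)nn3)cc1)CC2`. In this assay compound 2 gives > 50 ug/mL, again a limit rather than a number. Among the measured compounds shown here, on the values shown, compound 2 stands at the limit of > 50 ug/mL in this assay, at which 2 of the 2 values shown sit, so neither measured compound provides a number to compare against, and no step between two measured compounds exists. Compound 3, not yet measured, has the structure `COc1cc2c(cc1OC)CN(S(=O)(=O)c1ccc(-n3cc(COc4ccc(C)cc4)nn3)cc1)CC2`. It differs from compound 2 in one place: methyl in place of nitro on an aromatic carbon, in words methyl in place of nitro on an aromatic carbon. For the measured compounds named here, with no measured step to draw on, there is no basis for expecting a shift in either direction, and the estimate is for no change beyond the usual scatter. The expected step in this assay is a step that the limit leaves unreadable from compound 2 to compound 3. Compound 3 is therefore estimated to give about 70 ug/mL in this assay, with a likely range from 30 ug/mL to 200 ug/mL, most probably reported again only as a limit.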

Compound 3, half-maximal inhibitory concentration: > 50 ug/mL
Compound 3: a limit, no number; the forecaster's own chance of this, stated with the estimate: 80%; the middle value does not contradict the limit.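

No step can be read between compound 2 and compound 3, as the swap of nitro for methyl leaves both compounds at a limit of the assay and not at a number: the limit of > 50 ug/mL in this assay, at which 3 of the 3 values shown sit. The compounds shown leave open which change, if any, would give a measurable number in this assay.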